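Replacing the hexyl tail with a branched alkene

The compounds below may be only part of what the source reports. "The series", "measured", "known", "first", "only" and "open" are said of these compounds alone.

Compound 1 `CCCCn1ccc2cc(/C(C)=C/C(=O)Nc3ccccc3OCCCC(=O)O)ccc21`, compound 2 `CCCCCn1ccc2cc(/C(C)=C/C(=O)Nc3ccccc3OCCCC(=O)O)ccc21` and compound 3 `CCCCCCCn1ccc2cc(/C(C)=C/C(=O)Nc3ccccc3OCCCC(=O)O)ccc21` share one core and differ only in the chain on the aromatic nitrogen. In an assay on Prostate gland for inhibition of steroid 5-alpha-reductase (Rattus norvegicus) (on this read-out lower numbers stand for stronger inhibition and higher numbers for weaker inhibition), compound 1 gives 43 nM, compound 2 gives 23 nM, and compound 3 gives 120 nM, the highest number of the three. The measured steps read a 1.9-fold lower number from compound 1 to compound 2 (0.27 log units; within the scatter), a 2.8-fold higher number from compound 1 to compound 3 (0.45 log units; beyond the scatter) and a 5.2-fold higher number from compound 2 to compound 3 (0.72 log units; beyond the scatter). Compound 4 `CC(C)=CCn1ccc2cc(/C(C)=C/C(=O)Nc3ccccc3OCCCC(=O)O)ccc21` carries 2-methylprop-1-en-1-yl in place of hexyl on a saturated chain carbon bound to an aromatic nitrogen, so its chain is shorter again and holds a double bond. The steps leading to compound 3 bear on this: lengthening the chain raised the number, and shortening it back should lower it. Compound 4 is therefore expected to give 30 nM, between 12 nM and 80 nM. This corresponds to an expected 4.0-fold lower number from compound 3 to compound 4 (0.60 log units; beyond the scatter).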

Compound 4, half-maximal inhibitory concentration: 120 nM
Compound 4: middle estimate off by 4.0-fold (0.60 log units), on the low side; the whole stated range lies below it.
By their numbers in this assay, from the lowest: compounds 2 and 1 (each within the scatter of the next); then compounds 3 and 4 (each within the scatter of the next).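

In this assay, a smaller group did not by itself bring the number down: 2-methylprop-1-en-1-yl in place of hexyl gives (no change at the digits printed from compound 3 to compound 4 (within the scatter)). This group also falls short of the straight chains, with (a 5.2-fold higher number from compound 2 to compound 4 (0.72 log units; beyond the scatter)) and (a 2.8-fold higher number from compound 1 to compound 4 (0.45 log units; beyond the scatter)), so carbon count alone does not set the number at this position. Nothing available explains this difference. On these data alone, whether the branch or the double bond matters remains open. A saturated 3-methylbutyl chain, which keeps the branch without the double bond, would help separate the two.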